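Pyridin-2-yl to 3-methoxyphenyl: expected shift in a small series

The compounds below may be only part of what the source reports. "The series", "measured", "known", "first", "only" and "open" are said of these compounds alone.

Of the compounds shown here, three have numbers so far in a physicochemical assay for solubility, using the shake flask method, in phosphate buffer, with a stated time of 24 h, at pH 7.4; on this read-out lower numbers stand for lower solubility and higher numbers for higher solubility. Compound 1 (`Cn1ncc2c(=O)n(-c3ccccc3)c(COc3cccc(F)c3)nc21`) gives 194000 nM, compound 2 (`CC(Sc1nc2nn(CC3COC3)cc2c(=O)n1-c1ccccc1)c1ccccc1`) gives 77000 nM, and compound 3 (`CC(Sc1nc2c(cnn2C)c(=O)n1-c1ccccc1)c1ccccn1`) gives 20000 nM. Compound 3 is the lowest of the three, and its gaps to both others lie beyond the scatter, with compound 2 the nearest and compound 1 the furthest.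

The next entry is compound 4 (`COc1cccc(C(C)Sc2nc3c(cnn3C)c(=O)n2-c2ccccc2)c1`), not yet measured. It carries 3-methoxyphenyl in place of pyridin-2-yl on a saturated chain carbon bound to a saturated chain carbon and a sulfur.

Among the measured compounds shown here, no two measured compounds differ in one place only, so the series gives no direct measure of this swap in this assay. The working expectation is a moderate step downward, beyond the scatter, though a result within the scatter would not be surprising. For the measured compounds named here, the only anchor is compound 3 at 20000 nM, and the swap replaces its ring holding a hetero atom with a ring of carbon only. The expected change is a 2.5-fold lower number from compound 3 to compound 4 (0.40 log units; beyond the scatter). Compound 4 is estimated at 8000 nM, with an expected range of 2500 nM to 22000 nM.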

Compound 4, solubility: < 2000 nM
Compound 4: no number, only a limit; the forecaster's own chance of this, stated with the estimate: 5%; middle value at least 4.0-fold (0.60 log units) away from the limit.
By their numbers in this assay, from the lowest: compound 3; then compound 2; then compound 1. At a limit, below all of these: compound 4.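

In this assay compound 4 reads < 2000 nM, which is a limit of the assay and not a number. The series now has its first step between compounds that differ in one place, with 3-methoxyphenyl in place of pyridin-2-yl on a saturated chain carbon bound to a saturated chain carbon and a sulfur: an at least 10-fold lower number from compound 3 to compound 4 (1.00 log units; beyond the scatter). This position is therefore not indifferent to the change in this assay, although the size of the step is bounded on one side only and the reading for the new compound sits at the end of the usable range: the limit of < 2000 nM in this assay, at which 1 of the 4 values shown sits.

The change removes a ring with a hetero atom and adds a methoxy group in the same swap, and the compounds shown cannot separate these two parts, so which of them carries the step remains open. A pyridin-2-yl ring bearing a methoxy group at this place would divide the change in two, and an amine or a carboxylic acid on the ring would show whether the reading can be brought back up from the limit.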